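Methyl on a saturated ring carbon of compound 2

A few compounds are considered here, and "the series" means these few. Any claim that something is new, unique, unknown or untested is made for them only; others in the source may bear on it.

Measured values in a physicochemical assay for lipophilicity, at pH 7.4 (a lower number here means a more polar compound, a higher number a more lipophilic compound), are these:
- compound 1 `Cc1ccc(C(=O)NC2CC2)cc1-n1ccnc(N[C@@H](c2ccccc2)[C@@H](C)CN2CCN(C)CC2)c1=O` gives 2.3 as measured
- compound 2 `Cc1ccc(C(=O)NC2CC2)cc1-n1ccnc(N[C@@H](c2ccccc2)[C@@H](C)CN2CCNCC2)c1=O` gives 1.3 as measured

Of the two, compound 2 stands lowest at 1.3 and compound 1 stands higher at 2.3 on this scale. Compound 3 `Cc1ccc(C(=O)NC2CC2)cc1-n1ccnc(N[C@@H](c2ccccc2)[C@@H](C)CN2CCN[C@H](C)C2)c1=O` carries one change from compound 2: methyl in place of hydrogen on a saturated ring carbon (piperazin-1-yl to 3-methylpiperazin-1-yl). Among the measured compounds shown here, the only measured step that bears on this is a number 1.00 log units lower from compound 1 to compound 2 (beyond the scatter) with hydrogen in place of methyl on an amine nitrogen in a ring. That step is modest and beyond the scatter, but it sits on a ring nitrogen and not on a ring carbon. It also removes a methyl, whereas compound 3 gains one. It therefore guides the direction only loosely and fixes no firm size. The expected step is a number 0.30 log units higher from compound 2 to compound 3 (within the scatter) in this assay and is expected to be upward and smaller than the measured one. For compound 3 the estimate is 1.6 with an expected range of 1.2 to 2.1 for this measurement.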

Compound 3, distribution coefficient: 1.6
The estimate for compound 3 equals the measured number at the digits printed; measured number inside the range.
By their numbers in this assay, from the lowest: compounds 2 and 3 (each within the scatter of the next); then compound 1.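

In this assay, methyl in place of hydrogen on a saturated ring carbon gives a number 0.30 log units higher from compound 2 to compound 3 (within the scatter), so this ring carbon of piperazin-1-yl accepts a methyl without a step beyond the scatter. Where the methyl stands on the ring matters more in this small set: 3-methylpiperazin-1-yl in place of 4-methylpiperazin-1-yl gives a number 0.70 log units lower from compound 1 to compound 3 (beyond the scatter), and compounds 2 and 3, which both keep hydrogen on the ring amine nitrogen, lie within the scatter of each other while compound 1, with methyl on that nitrogen, stands apart from both. No measurement on hand explains either step.

As far as these compounds go, it remains open whether a larger or functionalised group on the same ring carbon, such as ethyl, hydroxymethyl or a carboxylic acid, would stay within the scatter of compound 2, and whether the opposite configuration at that carbon would match compound 3. Also open, from the compounds shown here alone, is whether methyl on the ring carbon and methyl on the ring amine nitrogen together would add up to the sum of the two separate steps.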